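Chloro on the benzyl ring of a dibromopyrrole amide

The source may report more compounds than this note shows. Statements on the series, on what has been measured and on what is new or still open speak of the compounds shown alone.

Measured compounds:
compound 1 `O=C(NCc1ccc(-c2ccccc2)cc1)c1ccc[nH]1` — > 50000 nM
compound 2 `O=C(NCc1ccccc1)c1cc(Br)c(Br)[nH]1` — 11000 nM

In a functional assay on SJ-G2 cells (Homo sapiens) for inhibition, read by MTT assay, with a stated time of 72 h (on this read-out lower numbers stand for stronger inhibition of growth and higher numbers for weaker inhibition of growth), compound 1 gives only > 50000 nM, which is a limit of the assay and not a number. Compound 2 gives 11000 nM in this assay, the only number shown among the two values. Compound 3 `O=C(NCc1ccc(Cl)cc1)c1cc(Br)c(Br)[nH]1` is not yet measured; it differs from compound 2 by chloro in place of hydrogen on an aromatic carbon. Going by the values given here, no step between measured compounds is available, so the expectation rests on compound 2 alone, and a small step, if any, is expected beyond the scatter. Compound 3 is estimated at 8000 nM, with a range from 2500 nM to 30000 nM, which means an expected step of a 1.4-fold lower number from compound 2 to compound 3 (0.14 log units; within the scatter).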

Compound 3, concentration for 50% growth inhibition: 28000 nM
For compound 3 the middle estimate is 3.5-fold (0.54 log units) below the measured one, within the range that was stated.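

Going by these compounds alone, on the benzyl ring, chloro on an aromatic carbon, para to a large group, gives the first step that can be read in this assay: a 2.5-fold higher number from compound 2 to compound 3 (0.41 log units; beyond the scatter). This single added heavy atom moves the read-out towards weaker inhibition of growth, and compound 3 still gives a number. Only compound 1 stays at a limit, which is not a number: the limit of > 50000 nM in this assay, at which 1 of the 3 values shown sits.

On these data alone, whether this shift is particular to chloro remains open, since a fluoro, a methoxy or an amine at this place could fall on either side of compound 2. As far as these compounds go, whether chloro elsewhere on the ring behaves the same also remains open.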